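This account rests on a few compounds, and the source may have more. Where it says the series, first, only, none or still open, it means among the compounds named here.

Among the compounds with values here, in a functional assay on MCF7 cells (Homo sapiens) for antiproliferative activity, read by MTT assay, with a stated time of 48 h (on this read-out higher numbers stand for weaker inhibition and lower numbers for stronger inhibition), only two compounds have been measured so far, and neither yields a number. Compound 1 (`COc1ccc(-c2c(Nc3ccc(NC(C)=O)cc3)c3ccccc3oc2=O)cc1`) gives > 100000 nM as a limit of the assay. Compound 2 (`COc1ccc(Nc2c(C(=O)C(F)(F)F)c(=O)oc3ccc(OC)cc23)cc1`) gives > 100000 nM as a limit too. Within the data shown here, the picture so far is thus a single one (the limit of > 100000 nM in this assay, at which 2 of the 2 values shown sit), and compound 2 offers no exact value to step from.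

Compound 3 (`COc1ccc2oc(=O)c(C(=O)C(F)(F)F)c(Nc3ccc(F)cc3)c2c1`) keeps the core of compound 2 and changes one substituent (fluoro in place of methoxy on an aromatic carbon): fluoro in place of methoxy on an aromatic carbon, turning 4-methoxyphenyl into 4-fluorophenyl. Among the measured compounds shown here, no measured step shows what this exchange does. With compound 2 resting on the limit of > 100000 nM in this assay, no change beyond the scatter is expected. The expected step of an at least 1.1-fold lower number from compound 2 to compound 3 (0.04 log units; that floor lies within the scatter) is therefore small, with no firm direction. Compound 3 is estimated at 90000 nM within a range from 25000 nM to 200000 nM and may again yield only a limit of the assay.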

Compound 3, half-maximal inhibitory concentration: > 100000 nM
Compound 3 was reported as a limit; the forecaster's own chance of this, stated with the estimate: 65%; middle value at least 1.1-fold (0.04 log units) away from the limit.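

Within the data shown here, compound 2 and compound 3 both rest on a limit of the assay, and no step for fluoro in place of methoxy can be read from them. The compounds shown leave open whether any change to the shared core yields an exact value: the limit of > 100000 nM in this assay, at which 3 of the 3 values shown sit.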